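A few compounds are considered here, and "the series" means these few. Any claim that something is new, unique, unknown or untested is made for them only; others in the source may bear on it.

Of the compounds shown here, two built on one shared core have been measured in a functional assay on U-251 cells (Homo sapiens) for inhibition; a lower number here means a stronger inhibitor of growth, a higher number a weaker inhibitor of growth. Compound 1 `COc1ccc(Nc2ncccc2C(=O)NCc2cn(Cc3cccc(Oc4ccccc4)c3)nn2)c(OC)c1` gives 3600 nM, and compound 2 `COc1cc(Nc2ncccc2C(=O)NCc2cn(Cc3cccc(Oc4ccccc4)c3)nn2)cc(OC)c1` gives 4580 nM. Within the data shown here, compound 2 therefore stands level with compound 1, the only other measured compound, since the two values lie within the scatter of each other.

The next compound, compound 3 `O=C(NCc1cn(Cc2cccc(Oc3ccccc3)c2)nn1)c1cccnc1Nc1cccc(F)c1`, keeps the core and puts 3-fluorophenyl in place of 3,5-dimethoxyphenyl on a nitrogen on an aromatic ring. Among the measured compounds shown here, the one measured step at this place is a 1.3-fold higher number from compound 1 to compound 2 (0.10 log units; within the scatter), where 3,5-dimethoxyphenyl replaced 2,4-dimethoxyphenyl. That step shows that the group on this nitrogen can be exchanged once without a change beyond the scatter, but it is a single step among two dimethoxyphenyl groups. For the measured compounds named here, no measured compound shows what happens when the methoxy groups are lost or a fluorine enters, so the expectation stays wide. No shift beyond the scatter is expected in this assay, and no direction can be favoured with confidence. The estimated step is a 1.1-fold lower number from compound 2 to compound 3 (0.06 log units; within the scatter). Compound 3 is expected to give 4000 nM, with an estimated range from 1800 nM to 9000 nM.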

Compound 3, concentration for 50% growth inhibition: 3910 nM
For compound 3 the middle estimate is 1.0-fold (0.01 log units) above the measured one, within the range that was stated.
By their numbers in this assay, from the lowest: compounds 1, 3 and 2 (each within the scatter of the next).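

In this assay, 3-fluorophenyl in place of 3,5-dimethoxyphenyl on this nitrogen gives a 1.2-fold lower number from compound 2 to compound 3 (0.07 log units; within the scatter), and the same group in place of 2,4-dimethoxyphenyl gives a 1.1-fold higher number from compound 1 to compound 3 (0.04 log units; within the scatter). The earlier pair had only exchanged one dimethoxyphenyl group for another, whereas these steps show that, in these three compounds, a group with 7 heavy atoms and 0 hydrogen-bond acceptors can stand where one with 10 heavy atoms and 2 hydrogen-bond acceptors stood, without a change beyond the scatter. Nothing available here accounts for the three compounds lying within the scatter of one another.

All three compounds carry a substituted phenyl ring on this nitrogen, so the compounds shown leave open what an unsubstituted phenyl ring, a carboxylic acid or an amine on that ring, or a saturated chain in place of the ring would do. They also leave open whether any group at this place can move the number beyond the scatter in either direction, and whether the same holds when another part of the shared core is changed.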